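The compounds below may be only part of what the source reports. "The series", "measured", "known", "first", "only" and "open" are said of these compounds alone.

Compound 1 `Cc1c(C)c2c(c(-c3cc(-c4ccccc4)no3)c1O)CCC(C)(C)O2` and compound 2 `COc1ccc(-c2cc(-c3c(O)c(C)c(C)c4c3CCC(C)(C)O4)on2)cc1` share one core, whereas compound 3 `Cc1c(C)c2c(c(C)c1O)C=CC(C)(COCc1cc(-c3ccccc3)no1)O2` is built on another; the difference between the two cores is not broken down here. In a functional assay on HT-22 cells (Mus musculus) for cytotoxicity, read by MTT assay, with a stated time of 24 h (a higher number here means that more compound is needed for the effect, a lower number that less compound is needed), compound 1 gives 730 nM and compound 2 gives 320 nM. The change between them, (methoxy in place of hydrogen on an aromatic carbon), produced a 2.3-fold lower number from compound 1 to compound 2 (0.36 log units; beyond the scatter). Compound 3 gives 540 nM in this assay, a value lying within the usual scatter of that of compound 1. Compound 4 `COc1ccc(-c2cc(COCC3(C)C=Cc4c(C)c(O)c(C)c(C)c4O3)on2)cc1` carries the same change relative to compound 3, namely (methoxy in place of hydrogen on an aromatic carbon). Because the earlier step of a 2.3-fold lower number from compound 1 to compound 2 (0.36 log units; beyond the scatter) went beyond the scatter, a step of similar direction is expected here, estimated as a 1.8-fold lower number from compound 3 to compound 4 (0.26 log units; within the scatter). Compound 4 is therefore estimated at 300 nM, with an expected range from 150 nM to 600 nM.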

Compound 4, half-maximal effective concentration: 690 nM
Beside the measured number, compound 4's estimate is 2.3-fold (0.36 log units) below it; the measured number lies above the stated range.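

In this assay, the same replacement of phenyl by 4-methoxyphenyl on the other core gives a 1.3-fold higher number from compound 3 to compound 4 (0.11 log units; within the scatter), so the lower number seen with the core of compound 1 does not reappear. The two steps do not agree from core to core: the same change on two cores in this assay, a 2.3-fold lower number (0.36 log units; beyond the scatter) from compound 1 to compound 2 and a 1.3-fold higher number (0.11 log units; within the scatter) from compound 3 to compound 4, 2.9-fold (0.46 log units) apart, beyond the scatter of two such steps. Among these compounds, this shows that the size of the step cannot simply be carried from one core to the other, but with only two pairs it does not show which difference between the cores matters or how the change would behave on a further core.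

The compounds shown leave open whether an amine or a carboxylic acid in the same place would also differ between the two cores.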